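The compounds below may be only part of what the source reports. "The series", "measured", "known", "first", "only" and "open" are said of these compounds alone.

Measured in an ADME assay (liver, Mus musculus) for metabolic stability, using microsomes; a higher number here means that the compound lasts longer, a lower number that the compound disappears faster:
- compound 1 `CCc1nc2cc(Cl)ccn2c1C(=O)NCc1ccc(N2CCCCC2)cc1`: 0.0383 h
- compound 2 `CCc1nc2cc(Cl)ccn2c1C(=O)NCc1ccc(N2CCCCCC2)cc1`: 0.0317 h

Going by the values given here, compound 1 stands level with compound 2, the only other measured compound, as the single measured step shows: a 1.2-fold lower number from compound 1 to compound 2 (0.08 log units; within the scatter).

Compound 3 `CCc1nc2cc(Cl)ccn2c1C(=O)NCc1ccc(N2CCC(c3ccc(Cl)cc3)CC2)cc1` keeps the core and amide of compound 1 and carries 4-chlorophenyl in place of hydrogen on a saturated ring carbon, three ring bonds from the ring nitrogen: 4-chlorophenyl in place of hydrogen on a saturated ring carbon.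

Among the compounds with values here, only that one measured step bears on this change, and only loosely. It also alters the saturated ring, but by changing the ring size, and it adds no aromatic ring. Within the data shown here, the series holds no measured example of a substituent on this ring, so the direction remains poorly defined. A step close to the scatter is the working expectation, with a slight lean towards a longer half-life and a wide margin on either side.

The expected change is a 1.3-fold higher number from compound 1 to compound 3 (0.12 log units; within the scatter). For compound 3 the estimated half-life is 0.05 h, with an expected range of 0.02 h to 0.15 h.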

Compound 3, half-life: 1.87 h
Estimate against measurement, compound 3: 37-fold (1.57 log units) below, outside the stated range (above it).
By their numbers in this assay, from the lowest: compounds 2 and 1 (each within the scatter of the next); then compound 3.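

In this assay, going by these compounds alone, the saturated ring carbon three ring bonds from the ring nitrogen proves highly sensitive to substitution: 4-chlorophenyl in place of hydrogen there gives a 49-fold higher number from compound 1 to compound 3 (1.69 log units; beyond the scatter), the first step beyond the scatter. The only earlier step, a 1.2-fold lower number from compound 1 to compound 2 (0.08 log units; within the scatter), changed the ring size, so the half-life in this series is shown to respond to a large group on this ring carbon, and not to the one change of ring size measured. Nothing measured here speaks to what lies behind the large step.

The compounds shown leave open whether the step depends on the chlorine, on the aromatic ring or simply on having a group at this carbon; phenyl without the chlorine, or methyl or hydroxyl on the same carbon, would tell these apart. Also open, as far as these compounds go, is whether 4-chlorophenyl on the azepan-1-yl ring of compound 2 would give a step of similar size.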